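Amide aryl replacements on the sulfonylurea series

This account rests on a few compounds, and the source may have more. Where it says the series, first, only, none or still open, it means among the compounds named here.

Measured so far:
compound 1 `Cc1ncsc1C(=O)NCCC1CCN(S(=O)(=O)NC(=O)NC[C@@H]2C[C@@H]3C=C[C@@H]2C3)CC1`, 11%
compound 2 `O=C(NC[C@@H]1C[C@@H]2C=C[C@@H]1C2)NS(=O)(=O)N1CCC(CCNC(=O)c2ccc3ccccc3n2)CC1`, 21%
compound 3 `O=C(NC[C@@H]1C[C@@H]2C=C[C@@H]1C2)NS(=O)(=O)N1CCC(CCNC(=O)c2cc(Cl)cc3cccnc23)CC1`, 35%

In a functional assay on the whole organism (blood) with Rattus norvegicus as the target, with stated times of 24 h and 1 h, at a dose of 5 mg/kg by the intraperitoneal route (on this read-out lower numbers stand for a weaker effect and higher numbers for a stronger effect at the one dose given), compound 3 stands highest of the three numbers, both steps to it beyond the scatter: a number 24 percentage points higher from compound 1 to compound 3 (beyond the scatter) and a number 14 percentage points higher from compound 2 to compound 3 (beyond the scatter), whereas a number 10 percentage points higher from compound 1 to compound 2 (within the scatter). Compound 4 `Cn1cc(C(=O)NCCC2CCN(S(=O)(=O)NC(=O)NC[C@@H]3C[C@@H]4C=C[C@@H]3C4)CC2)c(=O)n(C)c1=O` differs from compound 3 in one place: a group of 10 heavy atoms (6 carbon, 2 nitrogen, 2 oxygen; one six-membered aromatic ring with 2 hetero atoms) in place of a group of 11 heavy atoms (9 carbon, 1 nitrogen, 1 chlorine; one six-membered aromatic ring of carbon only, one six-membered aromatic ring with 1 hetero atom), on a carbonyl carbon. Going by the values given here, the steps that bear on this are the two onto the same carbonyl carbon, where 6-chloroquinolin-8-yl gave the higher read-out than 4-methyl-1,3-thiazol-5-yl or quinolin-2-yl. Compound 4 carries a single-ring group again, so a fall of modest size toward the number of compound 1 is expected, a number 20 percentage points lower from compound 3 to compound 4 (beyond the scatter). Compound 4 is expected to give 15%, within 5% to 28%.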

Compound 4, a percentage reported as activity, at one dose (the size of the read-out at that dose, not a potency): 23%
For compound 4 the middle estimate is 8 percentage points below the measured one; the range from low to high includes it.
By their numbers in this assay, from the lowest: compounds 1, 2 and 4 (each within the scatter of the next, the first and the last beyond it); then compound 3.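

In this assay, a single-ring group on this carbonyl carbon does not fix the read-out at the low end: the new group exceeds 4-methyl-1,3-thiazol-5-yl (a number 12 percentage points higher from compound 1 to compound 4 (beyond the scatter)) and cannot be told apart from quinolin-2-yl (a number 2 percentage points higher from compound 2 to compound 4 (within the scatter)). Replacing 6-chloroquinolin-8-yl still costs read-out (a number 12 percentage points lower from compound 3 to compound 4 (beyond the scatter)), leaving compound 3 alone at the top. Nothing at hand explains these steps.

Open, from the compounds shown here alone, is whether unsubstituted quinolin-8-yl or a phenyl group on the same carbonyl carbon would match compound 3, and so whether the chlorine goes with its higher number.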